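Replacing methyl with chloro in compound 3

The source may report more compounds than this note shows. Statements on the series, on what has been measured and on what is new or still open speak of the compounds shown alone.

Values measured in a physicochemical assay for lipophilicity, read by HPLC, at pH 7.4; a higher number here means a more lipophilic compound, a lower number a more polar compound:
- compound 1 `CCC/N=C1\S/C(=C\c2ccc(O)c(Cl)c2)C(=O)N1C1CCS(=O)(=O)CC1` gives 2.6
- compound 2 `CCC/N=C1\S/C(=C\c2ccc(O)c(C(F)(F)F)c2)C(=O)N1c1ccccc1C` gives 3.8
- compound 3 `CCC/N=C1\S/C(=C\c2ccc(O)c(C)c2)C(=O)N1c1ccccc1C` gives 3.8

In this assay compound 3 stands at 3.8, level with compound 2 at 3.8. Compound 1 lies clearly lower at 2.6. Going by the values given here, it also carries chloro, but no measured step links it to the other two through a single change, so it gives no size for the swap considered here.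

The next compound is compound 4 `CCC/N=C1\S/C(=C\c2ccc(O)c(Cl)c2)C(=O)N1c1ccccc1C`, and the change is chloro in place of methyl on an aromatic carbon. In short, this is chloro in place of methyl on an aromatic carbon.

Among the compounds with values here, only one measured step bears on this place in the structure: no change at the digits printed from compound 2 to compound 3 (within the scatter), for methyl in place of trifluoromethyl. With that single step as a guide, no shift beyond the scatter is expected in either direction. The estimated move is no change at the digits printed from compound 3 to compound 4 (within the scatter). Compound 4 is expected at 3.8, with an estimated range of 3.4 to 4.2.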

Compound 4, distribution coefficient: 3.8
Beside the measured number, compound 4's estimate shows no gap at the digits printed, and the stated range covers the measured number.
By their numbers in this assay, from the lowest: compound 1; then compounds 2, 3 and 4 (each within the scatter of the next).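

At this aromatic carbon, ortho to a hydroxy group, this assay gives chloro in place of methyl as no change at the digits printed from compound 3 to compound 4 (within the scatter) and chloro in place of trifluoromethyl as no change at the digits printed from compound 2 to compound 4 (within the scatter) so methyl, chloro and trifluoromethyl all read alike here. Compound 4 also gives the first single-change link to compound 1: 2-methylphenyl in place of 1,1-dioxothian-4-yl on the amide-type nitrogen in a ring is a number 1.20 log units higher from compound 1 to compound 4 (beyond the scatter) which makes the group on that nitrogen the only place shown so far where one change moves this number beyond the scatter. No measurement is available here that explains either result.

The compounds shown leave open how an amine or a carboxylic acid would read at this aromatic carbon. They also leave open whether methyl and chloro would still read alike with 1,1-dioxothian-4-yl on the nitrogen.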